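The source may hold more compounds than are shown below. What is called first, only, known or untested is meant among the compounds shown, and "the series" means these compounds.

Compound 1 `COc1ccc(CN(c2cc(OC)c(OC)c(OC)c2)S(=O)(=O)c2ccccc2)cc1` gives > 50000 nM in a functional assay on PC-3 cells (Homo sapiens) for inhibition, read by MTT assay, with a stated time of 48 h; on this read-out lower numbers stand for stronger inhibition and higher numbers for weaker inhibition.
Compound 2 `COc1cc(N(Cc2ccc(F)cc2)S(=O)(=O)c2ccc(C)cc2)cc(OC)c1OC` gives 20700 nM in this assay.

The value of compound 1 is a limit, not a number, as the limit of > 50000 nM in this assay, at which 1 of the 2 values shown sits, records. Compound 2 therefore stands alone as the only number shown, with 20700 nM in this assay. Compound 3 `COc1cc(N(Cc2csc3ccc(Cl)cc23)S(=O)(=O)c2ccc(C)cc2)cc(OC)c1OC` differs from compound 2 by 5-chloro-1-benzothiophen-3-yl in place of 4-fluorophenyl on a saturated chain carbon bound to a sulfonamide nitrogen. Among the compounds with values here, no step between measured compounds bears on this change, so the step from compound 2 to compound 3 is expected as a 2.6-fold lower number from compound 2 to compound 3 (0.41 log units; beyond the scatter), toward stronger inhibition, and is only an estimate. Compound 3 is estimated at 8000 nM in this assay, between 1500 nM and 40000 nM.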

Compound 3, half-maximal inhibitory concentration: 15300 nM
The estimate for compound 3 lay 1.9-fold (0.28 log units) below the measured number; the range from low to high includes it.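

In this assay, within the data shown here, the change at this position, on a saturated chain carbon bound to a sulfonamide nitrogen, gives a 1.4-fold lower number from compound 2 to compound 3 (0.13 log units; within the scatter) and is the first step that can be read there. The two-ring 5-chloro-1-benzothiophen-3-yl group thus reads alike with the one-ring 4-fluorophenyl group in this pair. Nothing shown accounts for this likeness.

The compounds shown leave open whether the plain 1-benzothiophen-3-yl group, without the chlorine, would read the same. They also leave open whether an amine or a carboxylic acid on this ring would move the number beyond the scatter.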